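Urea Anilinopyrimidines: Swapping the Aniline Ring in Compound 1

The compounds below may be only part of what the source reports. "The series", "measured", "known", "first", "only" and "open" are said of these compounds alone.

Measured so far:
- compound 1 `COc1ccc(Br)cc1Nc1cc(NC(=O)Nc2c(Cl)cccc2Cl)ncn1` — 53.3%
- compound 2 `COc1cc(NC(=O)Nc2cc(Nc3cc(Br)ccc3OC)ncn2)cc(OC)c1` — 23.1%

In a functional assay on NCI-H1581 cells (Homo sapiens) for inhibition, read by MTT assay, with a stated time of 48 h, tested at 10 uM (on this read-out lower numbers stand for less inhibition and higher numbers for more inhibition at the one concentration tested (going by the name of the read-out)), compound 1 gives 53.3% and holds the highest of the two numbers measured; the nearest neighbour is compound 2, which in this assay gives 23.1%, the step of a number 30.2 percentage points lower from compound 1 to compound 2 (beyond the scatter) lying beyond the scatter. That step concerns the amide-type nitrogen of the shared core, where 3,5-dimethoxyphenyl stood in place of 2,6-dichlorophenyl.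

Compound 3 `CCc1ccc(Nc2cc(NC(=O)Nc3c(Cl)cccc3Cl)ncn2)cc1` differs from compound 1 elsewhere: 4-ethylphenyl in place of 5-bromo-2-methoxyphenyl on a nitrogen on an aromatic ring. The urea side is left untouched. Within the data shown here, no measured step touches this nitrogen, so the one step on record, large as it is, does not bear directly on the change at hand. With no guide for this side of the molecule, an estimate must lean on compound 1 alone and be given a wide range. Compound 3 is therefore expected to give 42% (15% to 70%) in this assay, the expected step being a number 11.3 percentage points lower from compound 1 to compound 3 (beyond the scatter).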

Compound 3, a percentage reported as inhibition, at one concentration (the size of the read-out at that concentration, not a potency): 38.1%
For compound 3 the middle estimate is 3.9 percentage points above the measured one, and the stated range covers the measured number.
By their numbers in this assay, from the lowest: compound 2; then compound 3; then compound 1.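

In this assay, replacing 5-bromo-2-methoxyphenyl with 4-ethylphenyl on the nitrogen on an aromatic ring gives a number 15.2 percentage points lower from compound 1 to compound 3 (beyond the scatter), which shows that this side of the molecule, untouched by the earlier step, also moves the read-out while the 2,6-dichlorophenyl on the urea side stays the same. Among these compounds, compound 3 carries neither the bromo nor the methoxy group on this ring and still gives 38.1%, so inhibition at the one concentration tested does not depend on having both groups, although the single swap removes two groups and adds a third, and the step cannot be assigned to any one of them. No evidence at hand accounts for the size of this step.

The compounds shown leave open how much of the step belongs to the bromo group and how much to the methoxy group, and whether a phenyl ring carrying only one of them would stand nearer to compound 1. They also leave open how this position would respond to a longer chain in place of the ethyl group, or to an amine such as morpholine.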